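Resolved stereoisomer of compound 2: expected maximal response

This account rests on a few compounds, and the source may have more. Where it says the series, first, only, none or still open, it means among the compounds named here.

Measured compounds:
compound 1 `O=C(O)CNC(=O)c1ccc(C2CC2c2ccc(OCc3c(-c4c(Cl)cccc4Cl)noc3C3CC3)cc2Cl)cc1`, 100%
compound 2 `O=C(O)c1cccc(C2CC2c2ccc(OCc3c(-c4c(Cl)cccc4Cl)noc3C3CC3)cc2Cl)c1`, 102%
compound 3 `CC(C)n1nc(C(=O)O)cc1C1CC1c1ccc(OCc2c(-c3c(Cl)cccc3Cl)noc2C2CC2)cc1Cl`, 102%

In an assay on isolated protein for agonist activity at Bile acid receptor (Homo sapiens), read by FRET (on this read-out higher numbers stand for larger maximal responses and lower numbers for smaller maximal responses), compound 2 gives 102%. Compound 2 sits level with compound 3, the pair carrying the highest numbers of the three; compound 1 gives 100%, which falls within the scatter of compound 2. The single-change step no change at the digits printed from compound 2 to compound 3 (within the scatter) shows the maximal response unmoved when 3-carboxy-1-isopropyl-1H-pyrazol-5-yl replaces 3-carboxyphenyl on the saturated ring carbon. Compound 4 `O=C(O)c1cccc([C@@H]2C[C@H]2c2ccc(OCc3c(-c4c(Cl)cccc4Cl)noc3C3CC3)cc2Cl)c1` differs from compound 2 only in drawn stereochemistry: the two compounds have the same atoms and bonds; at least one stereo element is drawn with a configuration in one of them and without one in the other: 2 of 2 stereo elements differ; a stereocentre at a saturated ring carbon is drawn without a configuration in compound 2 and R in compound 4; a stereocentre at a saturated ring carbon is drawn without a configuration in compound 2 and R in compound 4. Among the compounds with values here, no measured step tests a change of this kind, and the number for compound 2 already describes material drawn without configuration. The expectation for compound 4 in this assay is therefore no change beyond the scatter, no change at the digits printed from compound 2 to compound 4 (within the scatter). Compound 4 is estimated at 102%, between 90% and 115%.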

Compound 4, largest response reached (reported as efficacy), in percent of the reference or control that the assay uses: 100%
The estimate for compound 4 lay 2 percentage points above the measured number, and the stated range covers the measured number.
By their numbers in this assay, from the lowest: compounds 1, 4, 2 and 3 (each within the scatter of the next).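

In this assay the step reads a number 2 percentage points lower from compound 2 to compound 4 (within the scatter). Within the data shown here, the earlier compounds varied only the acid-bearing group, whereas this step is the first test of configuration at the two saturated ring carbons, and drawing both as R leaves the maximal response within the scatter. It compares defined with undefined material, not two defined forms, because of how the pair differs: the fact that one of compounds 2 and 4 is drawn with a defined configuration and the other without, at the place where they differ

On these data alone, the opposite configuration at these carbons remains open, as does the same R,R form with 3-carboxy-1-isopropyl-1H-pyrazol-5-yl in place of 3-carboxyphenyl. Also open, as far as these compounds go, is whether a primary amide could stand in place of the carboxylic acid on the R,R form.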